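This account rests on a few compounds, and the source may have more. Where it says the series, first, only, none or still open, it means among the compounds named here.

Measured compounds:
compound 1, `COc1ccc(C(=O)Nc2ccccc2F)cc1OC1CCCC1`, 10700 nM
compound 2, `COc1ccc(C(=O)Nc2ccccc2Cl)cc1OC(=O)c1ccccc1`, > 1000000 nM

Within the data shown here, in an assay on isolated protein for inhibition of phosphodiesterase 4A (Sus scrofa) (a lower number here means a stronger inhibitor, a higher number a weaker inhibitor), compound 1 gives 10700 nM, the only number. Compound 2 is reported only as a limit of this assay, > 1000000 nM. Compound 2 differs from compound 1 in more than one place, so the two values can only be set side by side: compound 1 gives a number where compound 2 reaches no more than a limit, as noted in the limit of > 1000000 nM in this assay, at which 1 of the 2 values shown sits.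

Compound 3, `COc1ccc(C(=O)Nc2ncccc2C)cc1OC1CCCC1`, has not been measured. It differs from compound 1 in one place: 3-methylpyridin-2-yl in place of 2-fluorophenyl on an amide-type nitrogen. Among the measured compounds shown here, no measured pair in this set shows what such a change does in this assay, so the expected step rests on the structural change alone. A modest step towards stronger inhibition is expected from compound 1 to compound 3, a 3.1-fold lower number from compound 1 to compound 3 (0.49 log units; beyond the scatter), somewhat beyond the usual scatter but not large, given that compound 1 itself sits at 10700 nM.

Compound 3 is therefore estimated at 3500 nM in this assay, expected to fall between 600 nM and 20000 nM.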

Compound 3, half-maximal inhibitory concentration: 3100 nM
Compound 3: middle estimate off by 1.1-fold (0.05 log units), on the high side, within the range that was stated.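

Among these compounds, the exchange of 2-fluorophenyl for 3-methylpyridin-2-yl on the amide-type nitrogen gives the first measured step at this place in this assay: a 3.5-fold lower number from compound 1 to compound 3 (0.54 log units; beyond the scatter). The number at this place therefore responds to the aromatic group, and a group of the same heavy-atom count, with one hetero atom in its ring and one hydrogen-bond acceptor where 2-fluorophenyl has none, goes with a modest gain rather than a loss. Nothing measured for these compounds accounts for the size or direction of this step.

The change removes the fluorine, adds the methyl and brings a ring nitrogen all at once, so the compounds shown leave open which of these goes with the lower number; pyridin-2-yl without the methyl, or 3-methylphenyl, would pull them apart. Also open, on these data alone, is how far this place can be pushed, for instance with a 3-chloropyridin-2-yl or a 3-methoxypyridin-2-yl group, and whether the step holds when the cyclopentyl ether of the core is replaced by a shorter chain such as an ethyl ether.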